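Benzimidazole acylthiourea and acylurea series: cell growth inhibition notes

This account rests on a few compounds, and the source may have more. Where it says the series, first, only, none or still open, it means among the compounds named here.

Measured so far in a functional assay on SW-620 cells (Homo sapiens) for inhibition, read by MTT assay, with a stated time of 48 h; on this read-out lower numbers stand for stronger inhibition and higher numbers for weaker inhibition:
- compound 1, `Cc1ccc(NC(=S)NC(=O)c2ccc(OCc3ccccc3F)cc2)cc1-c1nc2ccccc2[nH]1`: 6440 nM
- compound 2, `Cc1ccc(COc2ccc(C(=O)NC(=S)Nc3ccc(C)c(-c4nc5ccccc5[nH]4)c3)cc2)cc1`: 60900 nM
- compound 3, `O=C(NC(=O)c1ccc(OCc2ccccc2F)cc1)Nc1ccc(Cl)c(-c2nc3ccccc3[nH]2)c1`: 2930 nM

Compound 3 gives the lowest of the three numbers in this assay; compound 1 stands nearest to it, and compound 2 furthest. The difference between the core of compound 1 and the core of compound 3 is not broken down here.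

One structural change is seen twice in the set. From compound 1 to compound 2 the change is 4-methylphenyl in place of 2-fluorophenyl on a saturated chain carbon bound to an oxygen on an aromatic ring and the step in this assay is a 9.5-fold higher number from compound 1 to compound 2 (0.98 log units; beyond the scatter). The unmeasured compound 4, `Cc1ccc(COc2ccc(C(=O)NC(=O)Nc3ccc(Cl)c(-c4nc5ccccc5[nH]4)c3)cc2)cc1`, relates to compound 3 by the same change, (4-methylphenyl in place of 2-fluorophenyl on a saturated chain carbon bound to an oxygen on an aromatic ring), made at the same place. Because the pair of compound 1 and compound 2 gave a 9.5-fold higher number from compound 1 to compound 2 (0.98 log units; beyond the scatter), the working expectation is that compound 4 moves in the same direction from compound 3, with a step estimated at a 6.8-fold higher number from compound 3 to compound 4 (0.83 log units; beyond the scatter). This rests on a single observed pair on a core that is not the core of compound 3, so the expected range is set wide. The estimate for compound 4 in this assay is 20000 nM, expected between 6000 nM and 70000 nM.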

Compound 4, half-maximal inhibitory concentration: 23200 nM
Estimate against measurement, compound 4: 1.2-fold (0.06 log units) below, within the range that was stated.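

In this assay the change from 2-fluorobenzyl to 4-methylbenzyl carries over to the second core in the same direction, with a 7.9-fold higher number from compound 3 to compound 4 (0.90 log units; beyond the scatter). Set beside the step on the core of compound 1, the size holds as well: the same change on two cores in this assay, a 9.5-fold higher number (0.98 log units; beyond the scatter) from compound 1 to compound 2 and a 7.9-fold higher number (0.90 log units; beyond the scatter) from compound 3 to compound 4, 1.2-fold (0.08 log units) apart, within the scatter of two such steps
This supports carrying the change between these two cores only, for this one pair of groups in this one cell read-out; it does not show that the step would hold on any other core, and it does not tell whether the loss of the fluorine, the gain of the methyl group or the different place of the substituent on the ring accounts for the step.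

Left open is whether a plain benzyl group, a methoxy-bearing benzyl group or a longer chain between the oxygen and the phenyl ring would give numbers nearer those of the 2-fluorobenzyl compounds or those of the 4-methylbenzyl compounds on either core. The core of compound 1 and the core of compound 3 also differ in more than one place, and no pair shown here separates those differences.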